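This account rests on a few compounds, and the source may have more. Where it says the series, first, only, none or still open, it means among the compounds named here.

Compound 1 `Cc1ncc(Cc2nc(-c3nc(C(F)(F)F)n[nH]3)n3ccccc23)cn1` gives 27 10^-6 cm/s in an ADME assay on MDCKII-LE cells (Canis lupus familiaris) for permeability, in the apical to basolateral direction; a lower number here means that the compound crosses the layer more slowly, a higher number that the compound crosses the layer faster.
Compound 2 `Fc1ccccc1Cc1nc(-c2ncn[nH]2)n2ccccc12` gives 8 10^-6 cm/s in this assay.

Among the measured compounds shown here, both compounds share the same core, and they differ in two places at once, so no single step between them can be read off. Of the two numbers measured, compound 2 stands lowest; compound 1 lies higher, and that gap is wider than the usual scatter of repeat measurements, so the two compounds do cross the cell layer at different rates.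

Compound 3 `Fc1ccccc1Cc1nc(-c2nc(Cc3ccccc3)n[nH]2)n2ccccc12` is the next compound in line and has not yet been measured. It is built from compound 2 by one change: benzyl in place of hydrogen on an aromatic carbon. For the measured compounds named here, no measured pair of compounds shows this same change, so there is no direct precedent for how large its effect will be. The change is expected to raise the number moderately, by a step of a 2.3-fold higher number from compound 2 to compound 3 (0.35 log units; beyond the scatter), a little beyond the scatter rather than within it. Compound 3 is estimated at 18 10^-6 cm/s, with a likely range from 7 10^-6 cm/s to 40 10^-6 cm/s.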

Compound 3, apparent permeability: 0.5 10^-6 cm/s
Compound 3: the middle estimate sits 36-fold (1.56 log units) above what was measured; measured number outside the range, below it.
By their numbers in this assay, from the lowest: compound 3; then compound 2; then compound 1.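

This position is far from neutral in this assay: the carbon between two ring nitrogen atoms of the five-membered aromatic ring carries hydrogen in compound 2, and placing benzyl there gives a 16-fold lower number from compound 2 to compound 3 (1.20 log units; beyond the scatter). Among the compounds shown here, this large step lies well beyond the scatter and is the first evidence of how much one added group on this carbon can shift the number, with the rest of the molecule unchanged. For the compounds shown here, it also shows that the step here is downward, although benzyl adds no hydrogen-bond donors, no hydrogen-bond acceptors and no net charge, and nothing measured so far explains why the number falls so sharply.

Going by these compounds alone, with only one change at this carbon to go on, it remains open whether the drop follows from benzyl as a whole or whether a single methyl, a longer chain such as phenylethyl, an amine or a carboxylic acid in the same place would move the number in the same direction and by a similar amount. On these data alone, it is also open whether benzyl would give a similar step when the 2-fluorophenyl part of compound 2 is replaced by another group.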